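The compounds below may be only part of what the source reports. "The series", "measured", "known", "first", "only" and "open" are said of these compounds alone.

Measured in a functional assay on Mahlavu cells (Homo sapiens) for antiproliferative activity, read by sulforhodamine B assay, with a stated time of 72 h; a higher number here means a weaker inhibitor, a lower number a stronger inhibitor:
compound 1 `Cc1ccccc1COc1ccc(-c2cc(CN3CCN(Cc4ccc(C(F)(F)F)cc4)CC3)no2)cc1` gives 6800 nM;
compound 2 `Cc1cccc(COc2ccc(-c3cc(CN4CCN(Cc5ccc(C(F)(F)F)cc5)CC4)no3)cc2)c1` gives 2500 nM;
compound 3 `Cc1cc(C)cc(COc2ccc(-c3cc(CN4CCN(Cc5ccc(C(F)(F)F)cc5)CC4)no3)cc2)c1` gives 6000 nM.

Compound 3 stands second highest of these three numbers, within the scatter of compound 1 and beyond it only from compound 2. Compound 4 `N#Cc1ccccc1COc1ccc(-c2cc(CN3CCN(Cc4ccc(C(F)(F)F)cc4)CC3)no2)cc1` differs from compound 3 by 2-cyanophenyl in place of 3,5-dimethylphenyl on a saturated chain carbon bound to an oxygen on an aromatic ring. Among the measured compounds shown here, no measured step exchanges a methyl for a nitrile, so only the shifts among methyl patterns bear on it: a 2.4-fold higher number from compound 2 to compound 3 (0.38 log units; beyond the scatter) and a 2.7-fold lower number from compound 1 to compound 2 (0.43 log units; beyond the scatter), both modest, while a 1.1-fold lower number from compound 1 to compound 3 (0.05 log units; within the scatter). With the nitrile untested, the step for compound 4 is expected to be no change at the digits printed from compound 3 to compound 4 (within the scatter), with wide uncertainty on either side. Compound 4 is therefore estimated at 6000 nM, in a range from 2000 nM to 20000 nM.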

Compound 4, half-maximal inhibitory concentration: 3500 nM
Estimate against measurement, compound 4: 1.7-fold (0.23 log units) above; the measured number falls inside the stated range.
By their numbers in this assay, from the lowest: compounds 2, 4, 3 and 1 (each within the scatter of the next, the first and the last beyond it).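

In this assay the first nitrile at this place, replacing the methyl of the 2-methylphenyl group, gives a 1.9-fold lower number from compound 1 to compound 4 (0.29 log units; within the scatter) so this swap leaves the number in the same range. The 2-cyanophenyl group also shows no clear separation from the other two methyl patterns, with a 1.7-fold lower number from compound 3 to compound 4 (0.23 log units; within the scatter) and a 1.4-fold higher number from compound 2 to compound 4 (0.15 log units; within the scatter) as the steps. No measurement shown here accounts for this result.

On these data alone, whether the nitrile would behave alike elsewhere on this ring stays open. So does whether a methoxy group, a chlorine or a carboxylic acid here would move the number beyond the scatter.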